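The source may report more compounds than this note shows. Statements on the series, on what has been measured and on what is new or still open speak of the compounds shown alone.

Compound 1 `Cc1nn([C@H]2C[C@H](O)[C@@H](CO)S2)c(=O)nc1N` — > 40000 nM
Compound 2 `CCc1nn([C@H]2C[C@H](O)[C@@H](CO)S2)c(=O)nc1O` — > 40000 nM

In an ADME assay on HEL cells (Homo sapiens) for cytotoxicity, read by microscopy (on this read-out higher numbers stand for lower toxicity in this test and lower numbers for higher toxicity in this test), compound 1 gives > 40000 nM, which is a limit of the assay and not a number. Compound 2 gives > 40000 nM in this assay, again a limit rather than a number. Compound 2 thus stands at the limit of > 40000 nM in this assay, at which 2 of the 2 values shown sit, and no number separates it from compound 1 in this assay.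

Compound 3 `Cc1nn([C@H]2C[C@H](O)[C@@H](CO)S2)c(=O)nc1O` has not yet been measured in this assay. It differs from compound 2 by hydrogen in place of methyl on a saturated chain carbon bound to an aromatic carbon. Within the data shown here, no step between measured compounds is available as a guide for this change. Given that both measured compounds sit at the limit, no shift beyond the usual scatter is expected in this assay, in either direction, and compound 3 is expected to report a limit as well.

The expected step of a number no higher from compound 2 to compound 3 (the limit leaves the size open) is taken as none beyond the scatter. Compound 3 is estimated at 40000 nM, within a range from 20000 nM to 80000 nM.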

Compound 3, minimum cytotoxic concentration: > 200000 nM
Compound 3 ended at the assay's limit (the forecaster's own chance of this, stated with the estimate: 85%); at least 5.0-fold (0.69 log units) between middle value and limit.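

In this assay, among these compounds, compound 1, compound 2 and compound 3 all report limits of the assay and not numbers, so no step among them can be read. The compounds shown leave open whether hydrogen in place of methyl, or hydroxy in place of amino, changes the minimum cytotoxic concentration at all.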